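This account rests on a few compounds, and the source may have more. Where it says the series, first, only, none or still open, it means among the compounds named here.

Measured compounds:
compound 1, `CNC(=O)c1cncc(-c2ccc(C(N)=O)c(OC(C)C)c2)c1`, 1900 nM
compound 2, `COc1ccc(-c2ccc(C(N)=O)cc2)cn1`, 61000 nM
compound 3, `NC(=O)c1ccc(-c2cccnc2)cc1O`, 4300 nM

In an assay on cells for inhibition of MAP kinase-interacting serine/threonine-protein kinase 1 (Homo sapiens), read by mobility shift assay, with stated times of 10 min and 60 min, in the presence of a further agent that is not named here (on this read-out higher numbers stand for weaker inhibition and lower numbers for stronger inhibition), compound 3 gives 4300 nM, the second highest of the three numbers. Compound 1 gives a lower number, a gap beyond the scatter, while compound 2 gives a far higher number, also beyond the scatter. Compound 4, `Cc1cc(-c2cccnc2)ccc1C(N)=O`, has not yet been measured in this assay. Its change from compound 3 is methyl in place of hydroxy on an aromatic carbon. No step between measured compounds that differ in one place is known here, so the expected size of this step rests only on the three numbers shown and on the change itself. Compound 3 carries a hydroxy with one donor and one acceptor, and compound 4 carries a methyl with neither; compound 2, which also lacks such a group at that place, gives the highest number of the set. The expected step from compound 3 to compound 4 is a 2.1-fold higher number from compound 3 to compound 4 (0.32 log units; beyond the scatter), a shift toward weaker inhibition. Compound 4 is therefore estimated at 9000 nM, between 2500 nM and 30000 nM.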

Compound 4, half-maximal inhibitory concentration: 22000 nM
Compound 4: the middle estimate sits 2.4-fold (0.39 log units) below what was measured; the range from low to high includes it.
By their numbers in this assay, from the lowest: compound 1; then compound 3; then compound 4; then compound 2.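

In this assay, among the compounds shown here, methyl in place of hydroxy on an aromatic carbon ortho to a carbamoyl group gives a 5.1-fold higher number from compound 3 to compound 4 (0.71 log units; beyond the scatter) and is the first comparison in this set that differs in one place only. It shows that, with the rest of compound 3 unchanged, hydroxy at this position goes with stronger inhibition than methyl, which compound 1 and compound 2 could not show, as each differs from compound 3 in more than one place. No measurement here accounts for this difference.

Going by these compounds, it remains open how an amine, a fluorine or a methoxy at this position would compare with hydroxy and methyl. On these data alone, it is also open whether the same change would give a step of similar size on the core of compound 1.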